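This account rests on a few compounds, and the source may have more. Where it says the series, first, only, none or still open, it means among the compounds named here.

In an ADME assay on cells (Erythrocyte, Homo sapiens), read by spectrophotometry and hemolysis, with a stated time of 1 h (a higher number here means that more compound is needed for the effect, a lower number that less compound is needed), compound 2 (`COc1ccc(-c2csc(N/N=C/c3ccc(C(F)(F)F)cc3)n2)cc1`) gives > 250 ug/mL, which is a limit of the assay and not a number. Compound 1 (`O=[N+]([O-])c1ccc(-c2csc(N/N=C/c3ccc(C(F)(F)F)cc3)n2)cc1`) gives > 250 ug/mL, again a limit. For the measured compounds named here, the one measured step, a step that the two limits leave unreadable from compound 1 to compound 2, therefore offers no size to carry forward. Compound 3 (`FC(F)(F)c1ccc(/C=N/Nc2nc(-c3ccc(Cl)c(Cl)c3)cs2)cc1`) differs from compound 2 by 3,4-dichlorophenyl in place of 4-methoxyphenyl on an aromatic carbon. Because the limit of > 250 ug/mL in this assay, at which 2 of the 2 values shown sit, holds for compound 1 and compound 2 alike, no step beyond the scatter is expected in this assay, though the data cannot exclude a drop. The expected change is estimated as a number no higher from compound 2 to compound 3 (the limit leaves the size open) in this case. For compound 3 the estimated value is 250 ug/mL, with an expected range from 100 ug/mL to 500 ug/mL, and a report of only a limit again seems likely.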

Compound 3, half-maximal effective concentration: > 250 ug/mL
Compound 3 was reported as a limit; the forecaster's own chance of this, stated with the estimate: 75%; the middle value sits exactly at the limit.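

In this assay compound 3 gives > 250 ug/mL, again a limit and not a number. No step among compound 1, compound 2 and compound 3 can be read: the limit of > 250 ug/mL in this assay, at which 3 of the 3 values shown sit.

The compounds shown leave open whether these three differ at all, and what actual value any of them has.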